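Moving a Chlorine on the Benzyl Arm

A few compounds are considered here, and "the series" means these few. Any claim that something is new, unique, unknown or untested is made for them only; others in the source may bear on it.

Measured so far:
compound 1, `CC1=C(C(=O)Nc2ccc(F)cc2)C(c2ccc([N+](=O)[O-])cc2)N=C(SCc2ccc(F)cc2)N1`, gives 17% in a functional assay on the whole organism (artery, strain albino) with Rattus norvegicus as the target, with a stated time of 120 min, at a dose of 10 mg/kg by the oral route; on this read-out lower numbers stand for less inhibition and higher numbers for more inhibition at the one dose given (going by the name of the read-out);
compound 2, `CC1=C(C(=O)Nc2ccc([N+](=O)[O-])cc2)C(c2ccc(Br)cc2)N=C(SCc2ccccc2Cl)N1`, gives 7.7% in this assay.

Compound 2 and compound 1 lie within the usual scatter of each other, so the two numbers cannot be told apart. Compound 3, `CC1=C(C(=O)Nc2ccc([N+](=O)[O-])cc2)C(c2ccc(Br)cc2)N=C(SCc2ccc(Cl)cc2)N1`, is not yet measured. It differs from compound 2 by 4-chlorophenyl in place of 2-chlorophenyl on a saturated chain carbon bound to a sulfur. For the measured compounds named here, no measured pair shows such a change, so the step from compound 2 to compound 3 is expected to stay within the scatter, with no clear direction. The estimated step is a number 2.3 percentage points higher from compound 2 to compound 3 (within the scatter). Compound 3 is therefore expected to give 10%, between 0% and 25%.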

Compound 3, a percentage reported as inhibition, in the whole organism at one dose (the size of the read-out at that dose, not a potency): 13.9%
Beside the measured number, compound 3's estimate is 3.9 percentage points below it, within the range that was stated.
By their numbers in this assay, from the lowest: compounds 2, 3 and 1 (each within the scatter of the next).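

For the compounds shown here, this is the first pair that differs in one place only, so the position of the chlorine on the benzyl arm can be judged alone. In this assay the change from 2-chlorobenzyl to 4-chlorobenzyl is a number 6.2 percentage points higher from compound 2 to compound 3 (within the scatter) and so does not separate the two compounds at this one dose. Nothing available gives a reason for this result. As far as these compounds go, whether an amine or a carboxylic acid on this ring, or a longer chain in place of the benzyl arm, would give a number beyond the scatter stays open.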